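Carbamate in place of the thiophene amide on the shared core

The source may hold more compounds than are shown below. What is called first, only, known or untested is meant among the compounds shown, and "the series" means these compounds.

Measured so far in a functional assay on PANC-1 cells (Homo sapiens) for inhibition, read by MTT assay, with a stated time of 24 h, tested at 10 uM; on this read-out lower numbers stand for less inhibition and higher numbers for more inhibition at the one concentration tested (going by the name of the read-out):
compound 1, `CC(C)=CCC1Cc2c(OC(=O)Nc3cccc(F)c3)cc(=O)n(CCCO)c2CC1(C)C`: 66.1%
compound 2, `CC(C)=CCC/C(C)=C/COc1cc(=O)n(CCCO)c2c1CC(C/C=C(\C)CCC=C(C)C)C(C)(C)C2`: 15.8%
compound 3, `CC(C)=CCC/C(C)=C/CC1Cc2c(OCCCNC(=O)c3cccs3)cc(=O)n(CCCO)c2CC1(C)C`: 72.8%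

Compound 3 stands highest of the three numbers; compound 1 lies nearest, within the scatter, and compound 2 lies furthest, beyond it. Among the compounds with values here, the only step with a counted difference is a number 57 percentage points higher from compound 2 to compound 3 (beyond the scatter), a change at the same oxygen on the aromatic ring as the one now considered, but of a different kind. Compound 4, `CC(C)=CCC/C(C)=C/CC1Cc2c(OC(=O)Nc3cccc(F)c3)cc(=O)n(CCCO)c2CC1(C)C`, carries (3-fluorophenyl)carbamoyl in place of 3-(((thiophen-2-yl)carbonyl)amino)propyl on an oxygen on an aromatic ring. Within the data shown here, no step is given between compound 1 and compound 3 or compound 4; compound 1 simply carries the same (3-fluorophenyl)carbamoyl group on an oxygen on an aromatic ring and, in this assay, gives a number within the scatter of compound 3. For compound 4 a step of a number 4.8 percentage points lower from compound 3 to compound 4 (within the scatter) is therefore expected, none beyond the scatter. Compound 4 is estimated at 68%, between 52% and 82%.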

Compound 4, a percentage reported as inhibition, at one concentration (the size of the read-out at that concentration, not a potency): 52.3%
Compound 4: the middle estimate sits 15.7 percentage points above what was measured; the measured number falls inside the stated range.
By their numbers in this assay, from the lowest: compound 2; then compound 4; then compounds 1 and 3 (each within the scatter of the next).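

On an oxygen on an aromatic ring, (3-fluorophenyl)carbamoyl in place of 3-(((thiophen-2-yl)carbonyl)amino)propyl gives a number 20.5 percentage points lower from compound 3 to compound 4 (beyond the scatter) in this assay so the two groups are not interchangeable there, yet the carbamate still gives a number 36.5 percentage points higher from compound 2 to compound 4 (beyond the scatter) against the 3,7-dimethylocta-2,6-dien-1-yl group at that oxygen. With the carbamate held fixed, the chain on the shared core also counts: a number 13.8 percentage points lower from compound 1 to compound 4 (beyond the scatter) is the step for 3-methylbut-2-en-1-yl in place of hydrogen on a saturated chain carbon bound to a double-bonded chain carbon. No supporting data bear on the origin of these steps.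

On these data alone, compound 3 and compound 4 differ in both the aromatic ring and the link to the oxygen, so the share of each in the step stays open. Also open, as far as these compounds go, is how an amine or a carboxylic acid at the end of the propyl chain on that oxygen would read.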